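Aryl change on the ring nitrogen: cytotoxicity notes

The source may report more compounds than this note shows. Statements on the series, on what has been measured and on what is new or still open speak of the compounds shown alone.

Two compounds of the shared core have numbers in an ADME assay on HEK293 cells (Homo sapiens) for cytotoxicity, read by MTT assay, with a stated time of 48 h; on this read-out higher numbers stand for weaker inhibition and lower numbers for stronger inhibition. Compound 1 `Cc1cc(C)cc(-n2cc(COC(=O)c3cc4ccccc4[nH]3)nn2)c1` gives 12500 nM in this assay. Compound 2 `CCCCc1ccc(-n2cc(COC(=O)c3cc4ccccc4[nH]3)nn2)cc1` gives 24200 nM in this assay. Compound 1 stands at the lower end of the two numbers shown, but the gap to compound 2 is within the scatter, so the two values show no separation. Within the data shown here, no step between measured compounds is available.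

Compound 3 `O=C(OCc1cn(-c2ccccc2Br)nn1)c1cc2ccccc2[nH]1` is not yet measured. It differs from compound 1 by 2-bromophenyl in place of 3,5-dimethylphenyl on an aromatic nitrogen. Among the measured compounds shown here, with only two measured values, and those within the scatter of each other, there is no basis for expecting a step beyond the scatter in either direction in this assay. The expected step from compound 1 to compound 3 is a 1.2-fold higher number from compound 1 to compound 3 (0.08 log units; within the scatter). Compound 3 is estimated to give 15000 nM, in a range from 5000 nM to 45000 nM.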

Compound 3, half-maximal inhibitory concentration: > 200000 nM
Compound 3: no number, only a limit (the forecaster's own chance of this, stated with the estimate: 15%); middle value at least 13-fold (1.12 log units) from the limit.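

Position note: the aryl group on the aromatic nitrogen can move the reading in this assay well beyond the scatter, which compound 1 and compound 2 did not show, as their values lay within the scatter of each other. Replacing 3,5-dimethylphenyl with 2-bromophenyl gives an at least 16-fold higher number from compound 1 to compound 3 (1.20 log units; beyond the scatter), so this change separates clearly where the earlier pair did not. The reading for compound 3 is a limit of the assay and not a number: the limit of > 200000 nM in this assay, at which 1 of the 3 values shown sits.

Still open, from the compounds shown here alone, is whether the step follows the bromine itself or the loss of the 3,5-dimethylphenyl group, since this single change does not separate the two. Also open, going by these compounds, is how a plain phenyl, a chlorophenyl or an aminophenyl group on the same aromatic nitrogen would read in this assay.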